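Swapping the Sulfonamide Amine in a Urea Series

A few compounds are considered here, and "the series" means these few. Any claim that something is new, unique, unknown or untested is made for them only; others in the source may bear on it.

Compound 1 `O=C(NCc1ccncc1)Nc1ccc(S(=O)(=O)NCc2ccccc2)cc1`: 102 nM
Compound 2 `O=C(NCc1ccncc1)Nc1ccc(S(=O)(=O)N2CCc3ccccc3C2)cc1`: 142 nM

Both compounds share one core and differ only in the group on the sulfonyl sulfur. For the measured compounds named here, in an assay on isolated protein for activation of Nicotinamide phosphoribosyltransferase (Homo sapiens) (a higher number here means that more compound is needed for the effect, a lower number that less compound is needed), compound 2 gives 142 nM; its only companion is compound 1, and the step of a 1.4-fold higher number from compound 1 to compound 2 (0.14 log units; within the scatter) lies within the scatter, so the two cannot be told apart. Compound 3 `CN(C1CCCC1)S(=O)(=O)c1ccc(NC(=O)NCc2ccncc2)cc1` has not yet been measured. Its change from compound 2 is cyclopentyl(methyl)amino in place of 1,2,3,4-tetrahydroisoquinolin-2-yl on a sulfonyl sulfur. Going by the values given here, the only measured step at this position, a 1.4-fold higher number from compound 1 to compound 2 (0.14 log units; within the scatter), shows that exchanging one amine for another here left the number essentially unchanged; that step is the sole guide, and it does not cover a group without an aromatic ring. A modest step, or none beyond the scatter, is therefore expected in this assay, namely a 1.4-fold higher number from compound 2 to compound 3 (0.15 log units; within the scatter). Compound 3 is estimated at 200 nM, with a range from 80 nM to 500 nM.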

Compound 3, half-maximal effective concentration: 123 nM
Compound 3: the middle estimate sits 1.6-fold (0.21 log units) above what was measured; the range from low to high includes it.
By their numbers in this assay, from the lowest: compounds 1, 3 and 2 (each within the scatter of the next).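

In this assay, cyclopentyl(methyl)amino on the sulfonyl sulfur brings no aromatic ring, yet it gives a 1.2-fold lower number from compound 2 to compound 3 (0.06 log units; within the scatter) and also a 1.2-fold higher number from compound 1 to compound 3 (0.08 log units; within the scatter). The earlier pair held only groups with a six-membered aromatic ring of carbon, so compound 3 adds that, in these three compounds, such a ring is not required to keep the number in this same range. No independent data explain why the three compounds cannot be told apart.

The compounds shown leave open whether any group on the sulfonyl sulfur can move the number beyond the scatter, for instance a morpholine ring or an amine carrying a carboxylic acid. They also leave open whether a very small group such as dimethylamino would behave the same way.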